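Swapping bromo for trifluoromethoxy in a cytotoxicity assay

The source may hold more compounds than are shown below. What is called first, only, known or untested is meant among the compounds shown, and "the series" means these compounds.

Measured so far:
- compound 1 `OCCCCCC(O)c1ccc(-c2ccc(Br)cc2)cc1` gives 20000 nM
- compound 2 `OCCCCCC(O)c1ccc(-c2ccc(Cl)cc2Cl)cc1` gives 8000 nM

Going by the values given here, in a functional assay on J774 cells (Mus musculus) for cytotoxicity, read by resazurin assay (a higher number here means a weaker inhibitor, a lower number a stronger inhibitor), compound 1 gives 20000 nM, the higher of the two numbers so far. Compound 2 gives 8000 nM, and that gap lies beyond the usual scatter of repeated measurements. Compound 1 is therefore the weaker inhibitor of this pair. The two compounds differ in more than one place, so their gap cannot be pinned on any single change.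

The next compound is compound 3 `OCCCCCC(O)c1ccc(-c2ccc(OC(F)(F)F)cc2)cc1`. It carries trifluoromethoxy in place of bromo on an aromatic carbon, para to a large group, and the rest of the core of compound 1 stays the same: trifluoromethoxy in place of bromo on an aromatic carbon.

Among the compounds with values here, no measured pair shows this swap or any other single change, so the expectation in this assay is only a cautious one. No shift beyond the scatter is expected, and the estimated move is a 1.3-fold lower number from compound 1 to compound 3 (0.12 log units; within the scatter). Compound 2 at 8000 nM shows that a different substitution can lower the number, so the estimate leans slightly that way. For compound 3 the estimated value is 15000 nM, with an expected range from 6000 nM to 40000 nM.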

Compound 3, half-maximal inhibitory concentration: 14000 nM
Beside the measured number, compound 3's estimate is 1.1-fold (0.03 log units) above it; measured number inside the range.
By their numbers in this assay, from the lowest: compounds 2, 3 and 1 (each within the scatter of the next, the first and the last beyond it).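

In this assay, putting trifluoromethoxy in place of bromo on an aromatic carbon, para to a large group, gives a 1.4-fold lower number from compound 1 to compound 3 (0.15 log units; within the scatter). Going by these compounds alone, this is the first single change that can be read, and because the step lies within the scatter, compound 1 and compound 3 count as alike in this assay. At this position, then, 5 heavy atoms with 1 hydrogen-bond acceptor can stand where 1 bromine atom stood, with no shift that can be told apart from the ordinary spread of repeated measurements, and no separate measurement is at hand to explain this result.

From the compounds shown here alone, one swap at one position says little about the position as a whole, so it remains open whether an amine, a carboxylic acid or a longer alkyl chain at this same aromatic carbon would give a step beyond the scatter. Going by these compounds, it also remains open whether any single change to the rest of the core of compound 1 would move the number more than this swap does.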